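Trading the Methoxyphenyl for a Difluorophenyl

A few compounds are considered here, and "the series" means these few. Any claim that something is new, unique, unknown or untested is made for them only; others in the source may bear on it.

Compound 1, `COc1cc2c(Oc3ccc(NC(=O)c4nn(-c5ccccc5)c(=O)cc4C)cc3F)ccnc2cc1OCCCN1CCN(C)CC1`, gives 130 nM in a functional assay on MKN-45 cells (Homo sapiens) for inhibition, read by MTT assay, with a stated time of 72 h; on this read-out higher numbers stand for weaker inhibition and lower numbers for stronger inhibition.
Compound 2, `COc1cc2c(Oc3ccc(NC(=O)c4nn(-c5ccccc5C)c(=O)cc4C)cc3F)ccnc2cc1OCCCN1CCN(C)CC1`, gives 1630 nM in this assay.
Compound 3, `COc1ccc(-n2nc(C(=O)Nc3ccc(Oc4ccnc5cc(OCCCN6CCN(C)CC6)c(OC)cc45)c(F)c3)c(C)cc2=O)cc1`, gives 1230 nM in this assay.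

Compound 3 stands second highest of the three numbers. Its nearest neighbour is compound 2, as a 1.3-fold lower number from compound 2 to compound 3 (0.12 log units; within the scatter) shows, and its furthest is compound 1. The three compounds share one core and differ only in the aryl group on the aromatic nitrogen: compound 1 carries a plain phenyl, and a 13-fold higher number from compound 1 to compound 2 (1.10 log units; beyond the scatter) together with a 9.5-fold higher number from compound 1 to compound 3 (0.98 log units; beyond the scatter) shows that either substituent on that ring raises the number well beyond the scatter.

Compound 4, `COc1cc2c(Oc3ccc(NC(=O)c4nn(-c5ccc(F)c(F)c5)c(=O)cc4C)cc3F)ccnc2cc1OCCCN1CCN(C)CC1`, has not yet been measured. It differs from compound 3 by 3,4-difluorophenyl in place of 4-methoxyphenyl on an aromatic nitrogen. For the measured compounds named here, no measured step covers fluorine on this ring; the two steps from compound 1 show that a methyl and a methoxy each cost potency, but a difluorophenyl is a different case, and the plain phenyl of compound 1 remains the best reference. A number lying between compound 1 and compound 3 is therefore expected, which amounts to a 3.1-fold lower number from compound 3 to compound 4 (0.49 log units; beyond the scatter). Compound 4 is estimated at 400 nM, with a range from 100 nM to 1500 nM.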

Compound 4, half-maximal inhibitory concentration: 120 nM
Beside the measured number, compound 4's estimate is 3.3-fold (0.52 log units) above it; measured number inside the range.
By their numbers in this assay, from the lowest: compounds 4 and 1 (each within the scatter of the next); then compounds 3 and 2 (each within the scatter of the next).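

In this assay, for the compounds shown here, the earlier compounds suggested that any substituent on the aryl ring on this nitrogen raises the number, but compound 4 goes against that reading: replacing the 4-methoxyphenyl gives a 10-fold lower number from compound 3 to compound 4 (1.01 log units; beyond the scatter), and replacing the 2-methylphenyl gives a 14-fold lower number from compound 2 to compound 4 (1.13 log units; beyond the scatter). Set against the plain phenyl, the 3,4-difluorophenyl group gives a 1.1-fold lower number from compound 1 to compound 4 (0.03 log units; within the scatter), so this substituted ring keeps the number of the unsubstituted one. The position therefore responds to which groups the ring carries and not merely to whether it carries any, with compound 2 and compound 3 as the substituted cases that lose potency and compound 4 as the one that does not.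

Nothing presented here accounts for why the two fluorines are tolerated when the methyl and the methoxy are not. The compounds shown leave open whether a single fluorine on the phenyl would behave like the pair, and whether chlorine, a nitrile or a trifluoromethyl group on this ring would keep the number or raise it.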